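A few compounds are considered here, and "the series" means these few. Any claim that something is new, unique, unknown or untested is made for them only; others in the source may bear on it.

Measured so far:
- compound 1, `CCNc1nc(-c2ccccc2)nc2c1nnn2Cc1ccccc1Cl`: 463 nM
- compound 2, `CCNc1nc(-c2ccccc2)nc2c1nnn2Cc1ccccc1F`: 11 nM

Compound 1 stands highest of the two numbers in an assay on Cerebral cortex for displacement of a labelled ligand from adenosine receptor A1 (Bos taurus); on this read-out higher numbers stand for weaker inhibition and lower numbers for stronger inhibition; its nearest neighbour is compound 2, reached by a 42-fold lower number from compound 1 to compound 2 (1.62 log units; beyond the scatter), a step that comes from fluoro in place of chloro on an aromatic carbon of the benzyl group.

Compound 3, `Clc1ccccc1Cn1nnc2c(NC3CCCCC3)nc(-c3ccccc3)nc21`, has not been measured. It differs from compound 1 in a different place: cyclohexyl in place of ethyl on a nitrogen on an aromatic ring whose other neighbour is aromatic carbon; read one bond further out, ethylamino becomes cyclohexylamino.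

Among the measured compounds shown here, the only measured step, that from compound 1 to compound 2, concerns the halogen on the benzyl ring and leaves the amino substituent untouched, so it does not bear on the change toward compound 3. For the measured compounds named here, no measured pair shows what enlarging the ethyl to a cyclohexyl does here, and the direction of any effect is unknown from these data. Compound 3 is therefore expected to stay near compound 1, with a step of a 1.5-fold lower number from compound 1 to compound 3 (0.19 log units; within the scatter) that is not expected to go clearly beyond the scatter. The estimate for compound 3 in this assay is 300 nM, within a range from 60 nM to 1500 nM.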

Compound 3, inhibition constant: 34 nM
For compound 3 the middle estimate is 8.8-fold (0.95 log units) above the measured one; measured number outside the range, below it.
By their numbers in this assay, from the lowest: compound 2; then compound 3; then compound 1.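

In this assay, with the chloro group on the benzyl group held constant, the change from ethylamino to cyclohexylamino is a 14-fold lower number from compound 1 to compound 3 (1.13 log units; beyond the scatter) and shows that the substituent on this nitrogen, like the halogen, can move the number well beyond the scatter. Compound 1 and compound 2 both carry ethyl on this nitrogen, so they could not show that a six-membered carbon ring is tolerated here, or that this change goes toward stronger inhibition in this assay. Nothing available here gives a reason for this step.

The compounds shown leave open whether the result depends on the ring itself or simply on the greater number of carbons, a question that a straight hexyl chain or a cyclopentyl group on the same nitrogen would help to separate. They also leave open whether the cyclohexyl and fluoro changes add up when combined, since cyclohexyl appears here only with the chloro group on the benzyl group, and whether a hydroxyl group on the cyclohexyl ring would keep the stronger inhibition.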